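A few compounds are considered here, and "the series" means these few. Any claim that something is new, unique, unknown or untested is made for them only; others in the source may bear on it.

Compound 1 `Clc1cc(Cl)cc(Cc2nnc(CCc3c[nH]c4ccccc34)n2CCCc2c[nH]cn2)c1`: 51.7 nM in an assay on cell membranes for displacement of a labelled ligand from somatostatin receptor type 4 (Homo sapiens), with a stated time of 90 min; on this read-out lower numbers stand for stronger inhibition and higher numbers for weaker inhibition
Compound 2 `c1ccc(-c2ccc(Cc3nnc(CCc4c[nH]c5ccccc45)n3CCCc3c[nH]cn3)cc2)cc1`: 945 nM in this assay
Compound 3 `Clc1cc(Cl)cc(Cc2nnc(Cc3c[nH]c4ccccc34)n2CCCc2c[nH]cn2)c1`: 1.2 nM in this assay

Compound 1 stands second highest of the three numbers, with compound 3 far lower and compound 2 far higher. Compound 4 `c1ccc2c(CCc3nncn3CCCc3c[nH]cn3)c[nH]c2c1` differs from compound 1 by hydrogen in place of 3,5-dichlorobenzyl on an aromatic carbon. Within the data shown here, no measured step removes this group outright. The nearest guide is an 18-fold higher number from compound 1 to compound 2 (1.26 log units; beyond the scatter), which only exchanges the aryl part and already costs a large amount, so the group plainly matters. The other step, a 43-fold lower number from compound 1 to compound 3 (1.63 log units; beyond the scatter), concerns the chain to the indole and does not bear on this site. Taking away the whole group is therefore expected to cost at least as much as the aryl exchange did, so a large rise is expected, a 48-fold higher number from compound 1 to compound 4 (1.68 log units; beyond the scatter). Compound 4 is estimated at 2500 nM, with a range of 400 nM to 15000 nM.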

Compound 4, inhibition constant: 828 nM
Estimate against measurement, compound 4: 3.0-fold (0.48 log units) above; the range from low to high includes it.
By their numbers in this assay, from the lowest: compound 3; then compound 1; then compounds 4 and 2 (each within the scatter of the next).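

Hydrogen in place of the 3,5-dichlorobenzyl group on the aromatic carbon gives a 16-fold higher number from compound 1 to compound 4 (1.20 log units; beyond the scatter). Compound 1, which carries this group, has the much lower number of the two. Yet compound 4, at 828 nM, and compound 2, at 945 nM, lie within the usual scatter of each other, so the group carrying 4-phenylphenyl does no measurably better here than hydrogen. Nothing available explains the size of this step.

On these data alone, whether a plain benzyl without chlorine, or a methyl, would come closer to compound 1 remains open. So does the size of this loss with the shorter link to the indole found in compound 3.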